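One Methoxy Added to Compound 2

The compounds below may be only part of what the source reports. "The series", "measured", "known", "first", "only" and "open" are said of these compounds alone.

In a functional assay on MDA-MB-231 cells (Homo sapiens), read by microscopy and transwell migration, with a stated time of 24 h (a higher number here means a weaker inhibitor, a lower number a stronger inhibitor), compound 1 `C#CCN(C(=O)c1ccccc1)c1nc(-c2ccc(C)cc2C)cs1` gives 321 nM. Compound 2 `COc1cc(-c2csc(NC(=O)c3ccccc3)n2)cc(OC)c1OC` gives > 50000 nM in this assay, and this is a limit of the assay, not a number. Compound 2 therefore has no exact place on the scale, and its structure differs from that of compound 1 in more than one place.

Compound 3 `COc1ccccc1C(=O)Nc1nc(-c2cc(OC)c(OC)c(OC)c2)cs1` is built from compound 2 with a single change: methoxy in place of hydrogen on an aromatic carbon. This is methoxy in place of hydrogen on an aromatic carbon, so the phenyl becomes 2-methoxyphenyl. Going by the values given here, no measured pair in this small set shows what such a change does in this assay. The expected a number no higher from compound 2 to compound 3 (the limit leaves the size open) is therefore none beyond the usual scatter, and a further limit in place of a number would be no surprise. For compound 3 the estimate is 50000 nM, with an expected range from 10000 nM to 100000 nM.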

Compound 3, half-maximal inhibitory concentration: 8500 nM
The estimate for compound 3 lay 5.9-fold (0.77 log units) above the measured number, and the stated range ends above it.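

In this assay, turning the phenyl of compound 2 into 2-methoxyphenyl gives an at least 5.8-fold lower number from compound 2 to compound 3 (0.76 log units; beyond the scatter). Going by these compounds alone, this is the first change in the set made in a single place, and it shows that this spot, on an aromatic carbon ortho to a large group, is not indifferent: one methoxy there is enough to bring a compound from beyond the limit onto the measurable scale. Compound 2 carries a limit and not a number, so the step has a lower end but no known full size: the limit of > 50000 nM in this assay, at which 1 of the 3 values shown sits.

As far as these compounds go, whether methoxy itself matters remains open, since another group at this spot, such as an amine or a longer ether chain, could give a different number. Also open, from the compounds shown here alone, is whether the same change would act in the same way on compound 1, which differs from compound 2 in more than one place.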